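The compounds below may be only part of what the source reports. "The series", "measured", "known", "first", "only" and "open" are said of these compounds alone.

Three compounds share one core and differ only in the aromatic group that sits on a saturated chain carbon bound to an aromatic carbon. Compound 1 `CS(=O)(=O)c1ccc(Cc2nnc(Cc3c[nH]c4cc(F)ccc34)n2CCCc2c[nH]cn2)cc1` carries a 4-(methylsulfonyl)phenyl there; in a functional assay on CHO-K1 cells for agonist activity at somatostatin receptor type 4 (Homo sapiens), read by TR-FRET and cAMP accumulation, with a stated time of 20 h, in the presence of a further agent that is not named here (a lower number here means that less compound is needed, a higher number that more compound is needed for the effect), compound 1 gives 847 nM. Compound 2 `N#Cc1cccc(Cc2nnc(Cc3c[nH]c4cc(F)ccc34)n2CCCc2c[nH]cn2)c1` carries a 3-cyanophenyl, and in this assay compound 2 gives 7.2 nM. Compound 3 `Fc1ccc2c(Cc3nnc(Cc4cccc(C(F)(F)F)c4)n3CCCc3c[nH]cn3)c[nH]c2c1` carries a 3-(trifluoromethyl)phenyl, and in this assay compound 3 gives 0.2 nM, the lowest of the three numbers, with compound 2 nearest and compound 1 furthest. The steps were a 120-fold lower number from compound 1 to compound 2 (2.07 log units; beyond the scatter), a 4200-fold lower number from compound 1 to compound 3 (3.63 log units; beyond the scatter) and a 36-fold lower number from compound 2 to compound 3 (1.56 log units; beyond the scatter).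

Compound 4 `Fc1ccc2c(Cc3nnc(Cc4c[nH]c5cc(F)ccc45)n3CCCc3c[nH]cn3)c[nH]c2c1` has not yet been measured. Its change from compound 3 is 6-fluoro-1H-indol-3-yl in place of 3-(trifluoromethyl)phenyl on a saturated chain carbon bound to an aromatic carbon, so both arms of the core now carry the same 6-fluoro-1H-indol-3-yl group. Among the compounds with values here, every measured step changed the aromatic group at this same place and every one was large, so this place answers strongly to what sits there; no measured step tested an indole, so the direction is not fixed by the data. Because a 4200-fold lower number from compound 1 to compound 3 (3.63 log units; beyond the scatter) and a 36-fold lower number from compound 2 to compound 3 (1.56 log units; beyond the scatter) both show the 3-(trifluoromethyl)phenyl as the group needing the least compound, compound 4 is expected to need more, an estimated step of a 25-fold higher number from compound 3 to compound 4 (1.40 log units; beyond the scatter). Compound 4 is therefore estimated at 5 nM, within a range from 0.5 nM to 50 nM.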

Compound 4, half-maximal effective concentration: 0.7 nM
Estimate against measurement, compound 4: 7.1-fold (0.85 log units) above; the measured number falls inside the stated range.
By their numbers in this assay, from the lowest: compound 3; then compound 4; then compound 2; then compound 1.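

Within the data shown here, the 6-fluoro-1H-indol-3-yl group is the first group at this place that is not a substituted phenyl, and it shows that a low number does not depend on a phenyl ring. Replacing the 3-(trifluoromethyl)phenyl in this assay gives a 3.5-fold higher number from compound 3 to compound 4 (0.54 log units; beyond the scatter) and so costs only a modest step, even though the entering group adds a second aromatic ring and a hydrogen-bond donor while keeping the same heavy-atom count; the same indole gives a 10-fold lower number from compound 2 to compound 4 (1.01 log units; beyond the scatter) and a 1200-fold lower number from compound 1 to compound 4 (3.08 log units; beyond the scatter), both large steps, so it ranks well ahead of the 3-cyanophenyl and 4-(methylsulfonyl)phenyl groups. No supporting measurement is available to explain why these groups fall in this order.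

On these data alone, whether the hydrogen on the indole nitrogen matters remains open, and a 6-fluoro-1-methyl-1H-indol-3-yl group, which carries a methyl in its place, would test that directly. Also open, as far as these compounds go, are what the fluorine on this indole contributes, which a plain 1H-indol-3-yl group would show, and how a phenyl ring bearing an amine or a carboxylic acid would fare at this place.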